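This account rests on a few compounds, and the source may have more. Where it says the series, first, only, none or still open, it means among the compounds named here.

Of the compounds shown here, three from this series have been tested in a functional assay on NCI-H460 cells (Homo sapiens) for cytotoxicity, read by sulforhodamine B assay, with a stated time of 48 h; on this read-out higher numbers stand for lower toxicity in this test and lower numbers for higher toxicity in this test. Compound 1 `ClCc1ccc(Cn2cnc3c(Cl)ncnc32)cc1` gives 26900 nM in this assay. Compound 3 `ClCc1ccc(Cn2cnc3c(Cl)nc(Cl)nc32)cc1` differs from compound 1 in one place, (chloro in place of hydrogen on an aromatic carbon), and in this assay compound 3 gives 28800 nM. The step of a 1.1-fold higher number from compound 1 to compound 3 (0.03 log units; within the scatter) is therefore small. Compound 2 `ClCc1cccc(Cn2cnc3ncnc(Cl)c32)c1` has the same atoms as compound 1 joined differently; the difference between the two cores is not broken down here. In this assay compound 2 gives 91200 nM, the highest of the three numbers, and its gap to compound 3 and to compound 1 lies beyond the scatter in both cases.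

Compound 4 `ClCc1cccc(Cn2cnc3nc(Cl)nc(Cl)c32)c1` has not yet been measured in this assay. It differs from compound 2 by chloro in place of hydrogen on an aromatic carbon. Within the data shown here, this is the same kind of change as the one from compound 1 to compound 3, made on the core of compound 2 instead of that of compound 1. The expectation for compound 4 rests on that one earlier step: because a 1.1-fold higher number from compound 1 to compound 3 (0.03 log units; within the scatter) stayed within the scatter, the number for compound 4 is expected to stay close to that of compound 2, with an estimated step of a 1.0-fold higher number from compound 2 to compound 4 (0.02 log units; within the scatter). On that basis compound 4 is estimated to give about 95000 nM in this assay, with a likely range from 45000 nM to 200000 nM.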

Compound 4, concentration lethal to 50% of the cells: 5490 nM
Estimate against measurement, compound 4: 17-fold (1.24 log units) above, outside the stated range (below it).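

On the core of compound 2, chloro in place of hydrogen on an aromatic carbon, between two ring nitrogen atoms, gives a 17-fold lower number from compound 2 to compound 4 (1.22 log units; beyond the scatter) in this assay, which on this read-out stands for higher toxicity in this test. Set beside the earlier step, the same change does not carry over from one core to the other in this assay: the same change on two cores in this assay, a 1.1-fold higher number (0.03 log units; within the scatter) from compound 1 to compound 3 and a 17-fold lower number (1.22 log units; beyond the scatter) from compound 2 to compound 4, 18-fold (1.25 log units) apart, beyond the scatter of two such steps. Among these compounds, this shows that, in this series, the size of the step on the core of compound 1 did not tell the size of the step on the core of compound 2, but with only one pair on each core it does not show why the two cores part, nor how the change would behave on any further core.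

The compounds shown carry only hydrogen or chloro at this place, so what an amine, a methoxy group or a methyl group there would do on either core remains open. Also open, on these data alone, is whether the gap between the two cores would persist if a longer chain, such as a chloroethyl group, took the place of the chloromethyl group that all four compounds share.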